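Swapping tert-butyl for benzyl on the amide nitrogen

A few compounds are considered here, and "the series" means these few. Any claim that something is new, unique, unknown or untested is made for them only; others in the source may bear on it.

Compound 1 `CCCn1c(SCc2cc([N+](=O)[O-])ccc2OC)nc2cc(NC(=O)NC(C)(C)C)ccc21` gives 120 nM in an assay on isolated protein for inhibition of Gonadotropin-releasing hormone receptor (Rattus norvegicus); a lower number here means a stronger inhibitor, a higher number a weaker inhibitor.
Compound 2 `CCCn1c(SCc2cc([N+](=O)[O-])ccc2OC)nc2cc(NC(=O)NC(C)(C)C)cc(C(=O)N(C)C)c21` gives 200 nM in this assay.
Compound 3 `CCCn1c(SCc2cc([N+](=O)[O-])ccc2OC)nc2cc(NC(=O)NC(C)(C)C)cc(C(=O)NC(C)(C)C)c21` gives 490 nM in this assay.

Among these three, compound 3 stands at the highest number, that is, as the weakest inhibitor of the set. The steps behind that position are a 1.7-fold higher number from compound 1 to compound 2 (0.22 log units; within the scatter), which stays within the scatter, then a 4.1-fold higher number from compound 1 to compound 3 (0.61 log units; beyond the scatter) and a 2.5-fold higher number from compound 2 to compound 3 (0.39 log units; beyond the scatter), both beyond the scatter. So far, then, the only change that moved the number clearly was putting a (tert-butyl)carbamoyl group onto the core, and the only change on the carbonyl carbon itself also pushed the number up.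

Compound 4 `CCCn1c(SCc2cc([N+](=O)[O-])ccc2OC)nc2cc(NC(=O)NC(C)(C)C)cc(C(=O)NCc3ccccc3)c21` keeps everything of compound 3 except that (benzyl in place of tert-butyl on an amide-type nitrogen). For the measured compounds named here, no measured step tests a benzyl group, so the expectation has to lean on the two steps toward compound 3: both went to higher numbers, and both were modest in size. For compound 4, a further modest rise, or no change beyond the scatter, is the expected outcome rather than a clear gain. The estimate for compound 4 is therefore 700 nM with a range from 250 nM to 2000 nM, meaning an expected step of a 1.4-fold higher number from compound 3 to compound 4 (0.15 log units; within the scatter).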

Compound 4, half-maximal inhibitory concentration: 130 nM
Compound 4: the middle estimate sits 5.4-fold (0.73 log units) above what was measured; the measured number lies below the stated range.
By their numbers in this assay, from the lowest: compounds 1, 4 and 2 (each within the scatter of the next); then compound 3.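

In this assay the group on the amide-type nitrogen matters in its own right: benzyl in place of tert-butyl gives a 3.8-fold lower number from compound 3 to compound 4 (0.58 log units; beyond the scatter) and so shows that the high number of compound 3 does not come with every carbamoyl group on the shared core. The other two new steps, a 1.5-fold lower number from compound 2 to compound 4 (0.19 log units; within the scatter) and a 1.1-fold higher number from compound 1 to compound 4 (0.03 log units; within the scatter), both stay within the scatter, so the benzylcarbamoyl group can be carried on the core with no measurable loss against plain hydrogen, something the (tert-butyl)carbamoyl group did not allow. Nothing available accounts for the gap between benzyl and tert-butyl on this nitrogen, so these numbers alone cannot say whether the aromatic ring or the extra carbons are what count.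

A longer chain ending in the same ring, such as phenethyl, would help separate those two readings, as would a cyclohexylmethyl group, which keeps the ring size without the aromatic ring. Also open, from the compounds shown here alone, is how a carboxylic acid or an amine placed on the benzyl ring would behave.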